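The compounds below may be only part of what the source reports. "The series", "measured", "known", "first", "only" and "open" are said of these compounds alone.

Measured in a functional assay on Hs-578T cells (Homo sapiens) for inhibition, read by sulforhodamine B assay, with a stated time of 48 h, tested at 10 uM; on this read-out lower numbers stand for less inhibition and higher numbers for more inhibition at the one concentration tested (going by the name of the read-out):
compound 1 `Brc1cn2ccnc2c(-c2ccc3ncn(C4CCCCC4)c3c2)n1` gives 16.1%
compound 2 `c1ccc(-c2cn3ccnc3c(-c3ccc4ncn(C5CCCCC5)c4c3)n2)cc1` gives 23.8%
compound 3 `COc1ccc(-c2cn3ccnc3c(-c3ccc4ncn(C5CCCCC5)c4c3)n2)cc1` gives 80%

Compound 3 stands highest of the three: a number 56.2 percentage points higher from compound 2 to compound 3 (beyond the scatter) and a number 63.9 percentage points higher from compound 1 to compound 3 (beyond the scatter) are both beyond the scatter, whereas a number 7.7 percentage points higher from compound 1 to compound 2 (within the scatter) stays within it. Compound 4 `O=Cc1ccc(-c2cn3ccnc3c(-c3ccc4ncn(C5CCCCC5)c4c3)n2)cc1` is not yet measured; it differs from compound 3 by formyl in place of methoxy on an aromatic carbon, on the aromatic carbon para to a large group, so that 4-methoxyphenyl becomes 4-formylphenyl. Among the measured compounds shown here, the only step that touches this position is a number 56.2 percentage points higher from compound 2 to compound 3 (beyond the scatter), which shows that what sits there can move the read-out a great deal; no measured step places formyl there, so direction and size rest on nothing firm. A fall is expected for compound 4, a number 35 percentage points lower from compound 3 to compound 4 (beyond the scatter), with wide uncertainty. The estimate for compound 4 is 45%, range 15% to 80%.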

Compound 4, a percentage reported as inhibition, at one concentration (the size of the read-out at that concentration, not a potency): 45.5%
For compound 4 the middle estimate is 0.5 percentage points below the measured one, and the stated range covers the measured number.
By their numbers in this assay, from the lowest: compounds 1 and 2 (each within the scatter of the next); then compound 4; then compound 3.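

Swapping 4-methoxyphenyl for 4-formylphenyl shows that this position does not treat its two-heavy-atom, one-acceptor groups alike (a number 34.5 percentage points lower from compound 3 to compound 4 (beyond the scatter)). Formyl still keeps a gain over the plain phenyl (a number 21.7 percentage points higher from compound 2 to compound 4 (beyond the scatter)) and over bromo (a number 29.4 percentage points higher from compound 1 to compound 4 (beyond the scatter)), so methoxy is not the only group here that lifts the read-out beyond the scatter, although it gives the larger lift. No measured evidence bears on the gap between formyl and methoxy.

Still open, going by these compounds, is how an amine, a hydroxy group or a carboxylic acid at this place would rank against formyl and methoxy. Also open, on these data alone, is whether the same order holds with a longer chain in place of the cyclohexyl group.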